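The source may hold more compounds than are shown below. What is called first, only, known or untested is meant among the compounds shown, and "the series" means these compounds.

Measured so far in a functional assay on the whole organism (stomach) with Rattus norvegicus as the target; on this read-out lower numbers stand for an effect already at smaller amounts and higher numbers for an effect only at larger amounts of compound:
Compound 1, `Cc1nc2c(COc3ccccc3)cccn2c1C`: compound 1 gives 6 mg/kg.
Compound 2, `Cc1nc2c(OCc3ccccc3)cccn2c1CCC#N`: compound 2 gives 1.5 mg/kg.
Compound 3, `Cc1nc2c(OCc3ccccc3)cccn2c1CO`: compound 3 gives 16 mg/kg.

Among these three, compound 3 stands highest in this assay; compound 1 comes nearest and compound 2 furthest. Among the compounds with values here, the only measured step touching this part of the structure is an 11-fold higher number from compound 2 to compound 3 (1.03 log units; beyond the scatter), which shows that what sits on this saturated carbon matters strongly. Compound 4, `Cc1nc2c(OCc3ccccc3)cccn2c1COC(=O)C(C)(C)C`, differs from compound 3 in one place: (tert-butyl)carbonyl in place of hydrogen on an oxygen on a saturated carbon. Within the data shown here, no measured step covers this kind of addition, so the direction is uncertain. Because an 11-fold higher number from compound 2 to compound 3 (1.03 log units; beyond the scatter) left the hydroxy compound with the higher number, a moderate fall is expected for compound 4, a 2.0-fold lower number from compound 3 to compound 4 (0.30 log units; within the scatter). For compound 4 in this assay the estimate is 8 mg/kg, with a range from 2 mg/kg to 30 mg/kg.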

Compound 4, dose for half-maximal effect: 8 mg/kg
The estimate for compound 4 equals the measured number at the digits printed; low and high end bracket the measured number.
By their numbers in this assay, from the lowest: compound 2; then compounds 1, 4 and 3 (each within the scatter of the next, the first and the last beyond it).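

In this assay, the ester shows a 2.0-fold lower number from compound 3 to compound 4 (0.30 log units; within the scatter), so the hydrogen of the hydroxy group can carry a (tert-butyl)carbonyl without a change beyond the usual scatter. The gap to the cyanomethyl compound remains, with a 5.3-fold higher number from compound 2 to compound 4 (0.73 log units; beyond the scatter), so neither the free hydroxy nor its ester matches the cyanomethyl group at this saturated carbon. No data here explain these results.

Going by these compounds, whether an amine, a carboxylic acid or a longer chain ending in a nitrile at this carbon would give a lower number remains open.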